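Replacing a Bulky Pyrazole with Pyridine: Expected Clearance

The source may hold more compounds than are shown below. What is called first, only, known or untested is meant among the compounds shown, and "the series" means these compounds.

Measured so far in an ADME assay (liver) for metabolic stability, with Liver microsome (Rattus norvegicus) as the target, using microsomes and NADPH, with a stated time of 30 min, tested at 1 uM; a lower number here means slower removal, a higher number faster removal of the compound:
- compound 1 `Nc1ccc(S(=O)(=O)N2CCN(c3ncc(C(O)(C(F)(F)F)C(F)(F)F)cc3C#CCO)CC2)cn1` gives 65 mL.min-1.g-1
- compound 2 `Cn1cc(-c2cc(C(O)(C(F)(F)F)C(F)(F)F)cnc2N2CCN(S(=O)(=O)c3ccc(N)nc3)CC2)cn1` gives 44 mL.min-1.g-1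
- compound 3 `CC(C)(C)n1cc(-c2cc(C(O)(C(F)(F)F)C(F)(F)F)cnc2N2CCN(S(=O)(=O)c3ccc(N)nc3)CC2)cn1` gives 459 mL.min-1.g-1

Compound 3 stands highest of these three numbers, with compound 1 the nearest and compound 2 the furthest. Compound 4 `Nc1ccc(S(=O)(=O)N2CCN(c3ncc(C(O)(C(F)(F)F)C(F)(F)F)cc3-c3cccnc3)CC2)cn1` is not yet measured; it differs from compound 3 by pyridin-3-yl in place of 1-(tert-butyl)-1H-pyrazol-4-yl on an aromatic carbon. Within the data shown here, two measured steps bear on this change: a 10-fold higher number from compound 2 to compound 3 (1.02 log units; beyond the scatter) and a 7.1-fold higher number from compound 1 to compound 3 (0.85 log units; beyond the scatter). Both show that the tert-butyl-bearing ring of compound 3 goes with a much higher number than either smaller group on the same carbon. Removing it for a pyridin-3-yl is therefore expected to give a large drop, an 8.3-fold lower number from compound 3 to compound 4 (0.92 log units; beyond the scatter), bringing compound 4 back near compounds 1 and 2. Compound 4 is estimated at 55 mL.min-1.g-1, with a likely range of 25 mL.min-1.g-1 to 130 mL.min-1.g-1.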

Compound 4, intrinsic clearance in microsomes: 20 mL.min-1.g-1
The estimate for compound 4 lay 2.8-fold (0.44 log units) above the measured number; measured number below the stated range.
By their numbers in this assay, from the lowest: compound 4; then compounds 2 and 1 (each within the scatter of the next); then compound 3.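

In this assay the pyridin-3-yl ring does more than undo the tert-butyl pyrazole, with a 23-fold lower number from compound 3 to compound 4 (1.36 log units; beyond the scatter). It also falls clear of both smaller groups, with a 2.2-fold lower number from compound 2 to compound 4 (0.34 log units; beyond the scatter) and a 3.3-fold lower number from compound 1 to compound 4 (0.51 log units; beyond the scatter), so this carbon still separates groups that carry no tert-butyl. Nothing measured here explains the fall. Still open, as far as these compounds go, is whether a plain phenyl ring or a pyridin-4-yl ring on this carbon would give a number as low, and whether an amine on the pyridin-3-yl ring would keep it there.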